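Swapping Fluoro for Chloro on a Fused Ring

This account rests on a few compounds, and the source may have more. Where it says the series, first, only, none or still open, it means among the compounds named here.

Of the compounds shown here, three have been measured in a functional assay on MV4-11 cells (Homo sapiens) for cytotoxicity, read by MTT assay, with a stated time of 72 h; a higher number here means a weaker inhibitor, a lower number a stronger inhibitor. Compound 1 `CC(C)(C)c1cc(NC(=O)Nc2ccc(-c3cn4cccc(F)c4n3)cc2)no1` carries a fluoro group on its fused ring system, and in this assay compound 1 gives 12.2 nM. Compound 2 `CC(C)(C)c1cc(NC(=O)Nc2ccc(-c3cn4cccc(Cl)c4n3)cc2)no1` is the same molecule with a chloro group at that place, and in this assay compound 2 gives 353 nM. The change from compound 1 to compound 2 is chloro in place of fluoro on an aromatic carbon and it produced a 29-fold higher number from compound 1 to compound 2 (1.46 log units; beyond the scatter).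

Compound 3 `CC(C)(C)c1cc(NC(=O)Nc2ccc(-c3cn4cc(F)ccc4n3)cc2)no1` has the same atoms as compound 1, joined differently; the difference between the two cores is not broken down here. In this assay compound 3 gives 20.9 nM, a number that lies within the usual scatter of the value for compound 1.

Compound 4 `CC(C)(C)c1cc(NC(=O)Nc2ccc(-c3cn4cc(Cl)ccc4n3)cc2)no1` has not been measured. Its relation to compound 3 is chloro in place of fluoro on an aromatic carbon. This is the same kind of change as that from compound 1 to compound 2, but the surroundings differ: in compound 1 the place is ortho to a fused ring, whereas in compound 3 it is para to a fused ring, while both places are two atoms from the ring nitrogen and meta to a fused ring.

Going by the values given here, the one measured example of this change, with its step of a 29-fold higher number from compound 1 to compound 2 (1.46 log units; beyond the scatter), points toward a weaker inhibitor, so compound 4 is expected to give 250 nM, somewhere between 40 nM and 1500 nM. Among the compounds with values here, that estimate means a step of a 12-fold higher number from compound 3 to compound 4 (1.08 log units; beyond the scatter), smaller than the measured one because the only measured example of this change is a 29-fold higher number from compound 1 to compound 2 (1.46 log units; beyond the scatter) at a place that differs, and a single example is a thin basis.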

Compound 4, half-maximal inhibitory concentration: 24.8 nM
The estimate for compound 4 lay 10-fold (1.00 log units) above the measured number; the whole stated range lies above it.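

On the core of compound 3, chloro in place of fluoro gives a 1.2-fold higher number from compound 3 to compound 4 (0.07 log units; within the scatter) in this assay, so compound 3 and compound 4 cannot be told apart in this read-out. This same swap was far larger on the core of compound 1, which shows that its size in this series does not carry over unchanged from one core to the other, and the gap between the two results is larger than measurement noise can explain: the same change on two cores in this assay, a 29-fold higher number (1.46 log units; beyond the scatter) from compound 1 to compound 2 and a 1.2-fold higher number (0.07 log units; within the scatter) from compound 3 to compound 4, 24-fold (1.39 log units) apart, beyond the scatter of two such steps

These two pairs do not show why the swap matters so much on one core and so little on the other, nor do they show how it would behave on any further core, since a comparison of two cases cannot separate the features that set them apart.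

The compounds shown carry only fluoro and chloro at these places, so it remains open whether a bromo group, a methyl group or a methoxy group would be tolerated as chloro is in compound 4 or lose as much as chloro does in compound 2. As far as these compounds go, it also remains open whether an amine at either place would widen or narrow the contrast between the two cores.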